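This account rests on a few compounds, and the source may have more. Where it says the series, first, only, none or still open, it means among the compounds named here.

The measured compounds in a functional assay on MCF7 cells (Homo sapiens) for antiproliferative activity; on this read-out lower numbers stand for stronger inhibition and higher numbers for weaker inhibition:
compound 1, `CCCn1c(Cc2cc(OC)c(OC)c(OC)c2)nc2c(N)ncnc21`, 46800 nM
compound 2, `CC/C=C\Cn1c(Cc2cc(OC)c(OC)c(OC)c2)nc2c(N)ncnc21`, 64600 nM
compound 3, `CC/C=C/Cn1c(Cc2cc(OC)c(OC)c(OC)c2)nc2c(N)ncnc21`, 46800 nM

Compound 3 stands level with compound 1 in this assay, and the two share the lowest of the three numbers; compound 2 lies a 1.4-fold lower number from compound 2 to compound 3 (0.14 log units; within the scatter) away, a gap within the scatter. The step from compound 3 to compound 4, `CCCCCn1c(Cc2cc(OC)c(OC)c(OC)c2)nc2c(N)ncnc21`, is butyl in place of but-1-en-1-yl on a saturated chain carbon bound to an aromatic nitrogen. Two kinds of measured step bear on it. Putting but-1-en-1-yl in place of ethyl on the saturated chain carbon bound to the aromatic nitrogen gave no change at the digits printed from compound 1 to compound 3 (within the scatter) and a 1.4-fold higher number from compound 1 to compound 2 (0.14 log units; within the scatter). Redrawing the double bond from Z to E gave a 1.4-fold lower number from compound 2 to compound 3 (0.14 log units; within the scatter), a step that rests on (the fact that compounds 2 and 3 differ only in the configuration as drawn). None of these alterations of the chain on the aromatic nitrogen moved the number beyond the scatter, so removing the double bond from that chain is expected to leave the number in this assay essentially where it is: the expected step is a 1.0-fold higher number from compound 3 to compound 4 (0.00 log units; within the scatter). Compound 4 is therefore estimated at 47000 nM, with a range from 20000 nM to 110000 nM.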

Compound 4, half-maximal inhibitory concentration: 61700 nM
Estimate against measurement, compound 4: 1.3-fold (0.12 log units) below, within the range that was stated.
By their numbers in this assay, from the lowest: compounds 1, 3, 4 and 2 (each within the scatter of the next).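

In this assay, butyl in place of but-1-en-1-yl on a saturated chain carbon bound to an aromatic nitrogen stays within the scatter from either drawn double-bond configuration, with a 1.3-fold higher number from compound 3 to compound 4 (0.12 log units; within the scatter) and a 1.0-fold lower number from compound 2 to compound 4 (0.02 log units; within the scatter). The fully saturated chain also extends the earlier comparison, since ethyl in place of hydrogen on a saturated chain carbon, three bonds along the chain from an aromatic nitrogen, gives a 1.3-fold higher number from compound 1 to compound 4 (0.12 log units; within the scatter), again within the scatter. Nothing available explains the size of these steps.

All four compounds carry only a plain hydrocarbon chain at this place. The compounds shown leave open whether a longer chain, or a chain ending in an amine or a carboxylic acid, would move the number beyond the scatter.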